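Hydroxy for amino in a nearly level pair

The source may report more compounds than this note shows. Statements on the series, on what has been measured and on what is new or still open speak of the compounds shown alone.

Among the compounds with values here, compound 2 `C=C1[C@H](n2cnc3c(N)ncnc32)O[C@H](CO)[C@H]1O` gives 131000 nM in a functional assay on MT4 cells (Homo sapiens) for inhibition (on this read-out lower numbers stand for stronger inhibition and higher numbers for weaker inhibition), and has only one measured neighbour to be compared with. Compound 1 `C=C1[C@H](n2cnc3c(O)nc(N)nc32)O[C@H](CO)[C@H]1O` gives 150000 nM in this assay and the two numbers lie within the usual scatter of each other, so neither can be ranked above the other.

Compound 3 `C=C1[C@H](n2cnc3c(O)ncnc32)O[C@H](CO)[C@H]1O` has no number yet. It differs from compound 2 at one place, with hydroxy in place of amino on an aromatic carbon.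

Within the data shown here, no measured pair shows this exact swap, so any expectation is loose. Compound 1 also carries a hydroxy at that same place and gives 150000 nM in this assay with no gap beyond the scatter from compound 2, so no large step is expected here. The estimated change is a 1.1-fold higher number from compound 2 to compound 3 (0.06 log units; within the scatter) in this assay and it is expected to stay within the scatter. For compound 3 the expected value is 150000 nM with an estimated range of 60000 nM to 350000 nM around it.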

Compound 3, half-maximal inhibitory concentration: > 200000 nM
Compound 3: only a limit was reported; the forecaster's own chance of this, stated with the estimate: 25%; middle value at least 1.3-fold (0.12 log units) from the limit.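

In this assay compound 3 gives > 200000 nM, which is a limit and not a number. Within the data shown here, this supplies the first direct pair for hydroxy in place of amino on this aromatic carbon next to the ring nitrogen, with an at least 1.5-fold higher number from compound 2 to compound 3 (0.18 log units; that floor lies within the scatter), and a second pair, which differs by the loss of an amino group, with an at least 1.3-fold higher number from compound 1 to compound 3 (0.12 log units; that floor lies within the scatter); each step is only a floor, and the swap brings no number back under the limit, so neither step shows a real loss of inhibition, yet neither rules one out. The comparison can reach no further than this cut-off, which now bounds part of the series: the limit of > 200000 nM in this assay, at which 1 of the 3 values shown sits.

On these data alone, how far compound 3 truly lies from compound 2 stays unknown, and a real gap of any size beyond the floor would fit these results. Also open, as far as these compounds go, is how other groups on this same aromatic carbon, such as a methoxy group, a methylamino group or a chlorine atom, would read on this measure, and whether any of them would give a clearly lower number than the amino group of compound 2.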